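Fluoro on the Core of an Inactive Sulfonamide Series

This account rests on a few compounds, and the source may have more. Where it says the series, first, only, none or still open, it means among the compounds named here.

Compound 1, `NS(=O)(=O)c1ccc(/N=C2\NC(=O)/C(=C3/C(=O)Nc4ccccc43)S2)cc1`, in a functional assay on Caco-2 cells (Homo sapiens) for antiproliferative activity, read by MTT assay (a lower number here means a stronger inhibitor, a higher number a weaker inhibitor), gives > 200000 nM, a limit of the assay and not a number.
Compound 2, `NS(=O)(=O)c1ccc(/N=C2\NC(=O)/C(=C3/C(=O)N(Cc4ccccc4)c4ccccc43)S2)cc1`, in this assay gives > 200000 nM, a limit of the assay.

Compound 1 stands at the limit of this assay: all that is known of it is the limit of > 200000 nM in this assay, at which 2 of the 2 values shown sit. Among the compounds with values here, the one measured step, a step that the two limits leave unreadable from compound 1 to compound 2, puts benzyl in place of hydrogen on an amide-type nitrogen in a ring, and because the limit of > 200000 nM in this assay, at which 2 of the 2 values shown sit, holds both values its size cannot be read in either direction.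

Compound 3, `NS(=O)(=O)c1ccc(/N=C2\NC(=O)/C(=C3/C(=O)Nc4ccc(F)cc43)S2)cc1`, differs from compound 1 by fluoro in place of hydrogen on an aromatic carbon. Within the data shown here, no measured step touches the six-membered aromatic ring of carbon only, so the measured data give no size to expect for this change. With compound 1 at the limit, compound 3 is expected to remain near that limit as well, with the step of a number no higher from compound 1 to compound 3 (the limit leaves the size open) expected to stay within the scatter if a number is read at all. For compound 3 the estimate in this assay is 200000 nM, with a range from 50000 nM to 1000000 nM, and most likely it is reported only as a limit.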

Compound 3, half-maximal inhibitory concentration: 59900 nM
Estimate against measurement, compound 3: 3.3-fold (0.52 log units) above; the measured number falls inside the stated range.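

Fluoro in place of hydrogen on an aromatic carbon gives an at least 3.3-fold lower number from compound 1 to compound 3 (0.52 log units; beyond the scatter), the first step in the series with any readable size, though that size is only a lower bound. This shows that the six-membered aromatic ring of carbon only, which the earlier step did not touch, is a place where one fluorine atom brings a number into this assay, and compound 3 is the only one of the three to have one. Compound 1 and compound 2 both stay at a limit of the assay, so the step between them cannot be read: the limit of > 200000 nM in this assay, at which 2 of the 3 values shown sit.

The true size of the fluoro step stays open, and so does whether chloro, methoxy or an amine on the same aromatic carbon would also leave the limit, since fluoro is the only group shown there. Going by these compounds, it is also open whether fluoro would act in the same way with benzyl on the amide-type nitrogen of compound 2, or whether a carboxylic acid could stand in place of the sulfonamide.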